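Cyanophenyl Replacing Difluorophenyl on a Shared Core

The compounds below may be only part of what the source reports. "The series", "measured", "known", "first", "only" and "open" are said of these compounds alone.

Of the compounds shown here, three on a shared core have been tested in a functional assay on KB cells (Homo sapiens) for inhibition, with a stated time of 72 h; on this read-out higher numbers stand for weaker inhibition and lower numbers for stronger inhibition. Compound 1 `COc1ccc(S(=O)(=O)N2CCc3cccc(-c4ccc(F)c(F)c4)c32)cc1` gives 45 nM, the lowest of the three numbers. Compound 2 `COc1ccc(S(=O)(=O)N2CCc3cccc(-c4ccc(F)cc4)c32)cc1` gives 86 nM, and compound 3 `COc1ccc(S(=O)(=O)N2CCc3cccc(-c4ccccc4)c32)cc1` gives 120 nM. The step of a 1.9-fold higher number from compound 1 to compound 2 (0.28 log units; within the scatter) is within the scatter, whereas the step of a 2.7-fold higher number from compound 1 to compound 3 (0.43 log units; beyond the scatter) is modest but beyond it; the step of a 1.4-fold higher number from compound 2 to compound 3 (0.14 log units; within the scatter) is again within the scatter.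

Compound 4 `COc1ccc(S(=O)(=O)N2CCc3cccc(-c4ccc(C#N)cc4)c32)cc1` has not yet been measured. It differs from compound 1 by 4-cyanophenyl in place of 3,4-difluorophenyl on an aromatic carbon. Going by these compounds, the measured steps bear on this only indirectly: they show that going from 3,4-difluorophenyl toward phenyl raises the number in this assay somewhat, but none of them introduces a 4-cyanophenyl group, so the effect of the nitrile is untested. On that basis compound 4 is expected to land near the phenyl and fluorophenyl compounds, with the step of a 2.4-fold higher number from compound 1 to compound 4 (0.39 log units; beyond the scatter) estimated as a modest rise at most. The estimate for compound 4 is 110 nM, with a range from 40 nM to 320 nM.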

Compound 4, half-maximal inhibitory concentration: 31.1 nM
Compound 4: middle estimate off by 3.5-fold (0.55 log units), on the high side; the whole stated range lies above it.
By their numbers in this assay, from the lowest: compounds 4, 1, 2 and 3 (each within the scatter of the next, the first and the last beyond it).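

In this assay, a single nitrile on the phenyl ring moves the number clearly at this position, with a 3.9-fold lower number from compound 3 to compound 4 (0.59 log units; beyond the scatter) for cyano in place of hydrogen and a 2.8-fold lower number from compound 2 to compound 4 (0.44 log units; beyond the scatter) for cyano in place of fluoro, whereas the earlier swap of fluoro for hydrogen stayed within the scatter. The 4-cyanophenyl and 3,4-difluorophenyl groups cannot be told apart, with a 1.4-fold lower number from compound 1 to compound 4 (0.16 log units; within the scatter) lying within the scatter, so this position accepts two differently substituted rings at about the same level. Nothing shown here explains why the nitrile has this effect.

Going by these compounds, it remains open how an amine, a carboxylic acid or a methoxy group on this phenyl ring would read in this assay. On these data alone, it is also open whether a ring carrying both a nitrile and a fluoro group would give a lower number than either alone.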